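A few compounds are considered here, and "the series" means these few. Any claim that something is new, unique, unknown or untested is made for them only; others in the source may bear on it.

Measured compounds in a functional assay on SW480 cells (Homo sapiens) for cytotoxicity, read by MTT assay, with a stated time of 48 h; on this read-out higher numbers stand for weaker inhibition and lower numbers for stronger inhibition:

- compound 1 `O=c1ccoc2cc(OCc3cn(Cc4ccccc4)nn3)ccc12`, compound 1 gives 42900 nM
- compound 2 `Cc1ccc(Cn2cc(COc3ccc4c(=O)ccoc4c3)nn2)cc1`, compound 2 gives 10400 nM
- compound 3 `O=c1ccoc2cc(OCc3cn(Cc4ccc(Cl)cc4Cl)nn3)ccc12`, for compound 3 only a limit is recorded, > 100000 nM

Compound 1, the unsubstituted benzyl member of the series, stands highest of the two numbers available in this assay; its nearest neighbour is compound 2, with a 4.1-fold lower number from compound 1 to compound 2 (0.62 log units; beyond the scatter). Compound 3 sits at the limit of > 100000 nM in this assay, at which 1 of the 3 values shown sits. The two steps that lead to compound 3 both run upward: an at least 2.3-fold higher number from compound 1 to compound 3 (0.36 log units; beyond the scatter) and an at least 9.6-fold higher number from compound 2 to compound 3 (0.98 log units; beyond the scatter).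

Compound 4 `O=c1ccoc2cc(OCc3cn(Cc4cccc(F)c4)nn3)ccc12` differs from compound 1 by fluoro in place of hydrogen on an aromatic carbon. For the measured compounds named here, of the measured steps, the one from compound 1 to compound 2 is the closest in kind, a single small group added to the benzyl ring, and it gave a modest fall in the number. The steps to compound 3, which add two chloro groups, go the other way. A single fluoro on the benzyl ring, meta to a large group, is therefore expected to move the number little, if at all, with the direction uncertain.

For compound 4 the expected value in this assay is 35000 nM, within 12000 nM to 100000 nM, which corresponds to an expected step of a 1.2-fold lower number from compound 1 to compound 4 (0.09 log units; within the scatter).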

Compound 4, half-maximal inhibitory concentration: > 100000 nM
Compound 4 was reported as a limit; the forecaster's own chance of this, stated with the estimate: 10%; at least 2.8-fold (0.45 log units) between middle value and limit.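

In this assay, the change from hydrogen to fluoro on the benzyl ring gives an at least 2.3-fold higher number from compound 1 to compound 4 (0.36 log units; beyond the scatter), so a rise no longer requires the two chloro groups of compound 3: a single added atom is enough. Set against the 4-methylphenyl member, the 3-fluorophenyl group gives an at least 9.6-fold higher number from compound 2 to compound 4 (0.98 log units; beyond the scatter), which shows that in these compounds the two single-group changes on the ring, methyl and fluoro, move the number in opposite directions from compound 1. Compound 3 and compound 4 are both recorded only as limits, so the step between them cannot be read: the limit of > 100000 nM in this assay, at which 2 of the 4 values shown sit.

How far the true value of compound 4 lies beyond its limit remains unknown, and the compounds shown cannot separate the effect of fluoro itself from that of its place on the ring. Going by these compounds, it also remains open whether an amine, a carboxylic acid or a methoxy group on the same ring would follow compound 2 towards a lower number or compound 4 towards a higher one.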